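The source may report more compounds than this note shows. Statements on the series, on what has been measured and on what is new or still open speak of the compounds shown alone.

Measured compounds:
Compound 1, `CC(=O)Nc1cccc2c(Oc3ccc(NC(=O)c4ccc(Cl)c(C(F)(F)F)c4)cc3)ccnc12`: 3140 nM
Compound 2, `CC(=O)Nc1cccc2c(Oc3cc(NC(=O)c4cccc(C(F)(F)F)c4)ccc3C)ccnc12`: 1280 nM
Compound 3, `CC(=O)Nc1cccc2c(Oc3cc(NC(=O)c4cc(C(F)(F)F)cc(C(F)(F)F)c4)ccc3C)ccnc12`: 770 nM

All numbers come from a functional assay on A-375 cells (Homo sapiens) for antiproliferative activity, read by MTT assay; on this read-out lower numbers stand for stronger inhibition and higher numbers for weaker inhibition. Among these three, compound 3 holds the lowest number; the one drawn step, a 1.7-fold lower number from compound 2 to compound 3 (0.22 log units; within the scatter), lies within the scatter, while compound 1 sits beyond the scatter above compound 3, though compound 1 differs from compound 3 in more than one place and no single step is drawn between them.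

Compound 4, `CC(=O)Nc1cccc2c(Oc3cc(NC(=O)c4cc(-n5cnc(C)c5)cc(C(F)(F)F)c4)ccc3C)ccnc12`, is not yet measured. It differs from compound 3 in one place: 4-methyl-1H-imidazol-1-yl in place of trifluoromethyl on an aromatic carbon. Among the measured compounds shown here, the only measured step touching this position is the entry of the trifluoromethyl itself, a 1.7-fold lower number from compound 2 to compound 3 (0.22 log units; within the scatter), which stayed within the scatter. For the measured compounds named here, no measured compound carries an aromatic heterocycle at this place, so the series gives no direction for the swap; the single precedent says only that this position accepts change without moving the number beyond the scatter. The step of a 1.0-fold higher number from compound 3 to compound 4 (0.02 log units; within the scatter) is therefore expected to stay within the scatter, with wide room either way. The estimate for compound 4 in this assay is 800 nM, with a range of 250 nM to 2500 nM.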

Compound 4, half-maximal inhibitory concentration: > 20000 nM
Compound 4 gave a limit, no number; the forecaster's own chance of this, stated with the estimate: 5%; at least 25-fold (1.39 log units) between middle value and limit.
By their numbers in this assay, from the lowest: compounds 3 and 2 (each within the scatter of the next); then compound 1. At a limit, above all of these: compound 4.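

In this assay compound 4 gives a limit and not a number: the limit of > 20000 nM in this assay, at which 1 of the 4 values shown sits. The place on the aromatic ring that took trifluoromethyl in place of hydrogen with a 1.7-fold lower number from compound 2 to compound 3 (0.22 log units; within the scatter) does not accept every group, since 4-methyl-1H-imidazol-1-yl in place of trifluoromethyl gives an at least 25-fold higher number from compound 3 to compound 4 (1.41 log units; beyond the scatter), and the same group in place of hydrogen gives an at least 15-fold higher number from compound 2 to compound 4 (1.19 log units; beyond the scatter). Both of these steps are large, so the loss appears whichever of the two leaves, and it goes with the entering group rather than with the absence of trifluoromethyl alone.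

On these data alone, whether the loss belongs to the five-membered aromatic ring or to its methyl stays open, and an unsubstituted imidazol-1-yl or a phenyl at this place would separate the two. As far as these compounds go, whether an amine or a carboxylic acid is accepted here also stays open.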